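From nitro to methoxy, starting at a limit

The compounds below may be only part of what the source reports. "The series", "measured", "known", "first", "only" and "open" are said of these compounds alone.

Measured so far in a functional assay on A549 cells (Homo sapiens) for cytotoxicity, read by MTT assay, with a stated time of 72 h; a lower number here means a stronger inhibitor, a higher number a weaker inhibitor:
- compound 1 (`CNC(=O)c1cc(Oc2ccc(C(=O)/C=C/c3ccc([N+](=O)[O-])cc3)cc2)ccn1`): > 50000 nM (a limit, not a number)
- compound 2 (`CNC(=O)c1cc(Oc2ccc(C(=O)/C=C/c3cc(OC)c(OC)c(OC)c3)cc2)ccn1`): 9500 nM (a number)

Compound 1 stands at a limit of this assay and has no number yet: its > 50000 nM is only that limit. Compound 3 (`CNC(=O)c1cc(Oc2ccc(C(=O)/C=C/c3ccc(OC)cc3)cc2)ccn1`) has not yet been measured. Its difference from compound 1 is methoxy in place of nitro on an aromatic carbon in other words methoxy in place of nitro on an aromatic carbon, para to a large group. For the measured compounds named here, no measured step yet shows what this swap does, so any forecast stays loose. Going by the values given here, with compound 2 at 9500 nM as the one real number, a shift toward stronger inhibition is expected, of uncertain size. The estimated change is an at least 2.5-fold lower number from compound 1 to compound 3 (0.39 log units; beyond the scatter) and it is only an expectation. For compound 3 the expected value is 20000 nM with an estimated range from 7000 nM to 50000 nM in this assay.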

Compound 3, half-maximal inhibitory concentration: > 50000 nM
Compound 3: no number, only a limit; the forecaster's own chance of this, stated with the estimate: 30%; middle value at least 2.5-fold (0.39 log units) away from the limit.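

In this assay, for the compounds shown here, compound 1 and compound 3 both stand at a limit and have no number, so no step from one to the other can be read: the limit of > 50000 nM in this assay, at which 2 of the 3 values shown sit.

The compounds shown leave open whether methoxy in place of nitro changes the result at all, and by how much.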